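This account rests on a few compounds, and the source may have more. Where it says the series, first, only, none or still open, it means among the compounds named here.

Measured compounds:
compound 1, `O=C(O)C(=O)/C=C(\O)c1ccccc1`, 0%
compound 2, `O=C(O)C(=O)/C=C(\O)c1ccccc1Cl`, 33%
compound 3, `COC(=O)C(=N)/C=C(\O)c1ccc(Cl)cc1`, 13%

All three were run in an assay for inhibition of kynurenine 3-monooxygenase (Rattus norvegicus), tested at 10 uM; on this read-out higher numbers stand for more inhibition at the one concentration tested (going by the name of the read-out) and lower numbers for less inhibition. Compound 1 gives 0%, compound 2 gives 33% and compound 3 gives 13%. Among the compounds with values here, the one counted step, a number 33 percentage points higher from compound 1 to compound 2 (beyond the scatter), came from chloro in place of hydrogen on an aromatic carbon. Compound 3 is built on a different core; the difference between the two cores is not broken down here. Its number stands second of three, beyond the scatter from both compound 1 and compound 2.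

Compound 4, `COC(=O)C(=N)/C=C(\O)c1ccc(Cl)c(Cl)c1`, has not yet been measured. It differs from compound 3 by chloro in place of hydrogen on an aromatic carbon. This is the same kind of change as that from compound 1 to compound 2, not the same: in compound 2 the chloro sits ortho to a group of 8 heavy atoms, whereas in compound 4 it sits ortho to a chloro group (1 heavy atom) and meta to a group of 9 heavy atoms, on the other core. Within the data shown here, because the step of a number 33 percentage points higher from compound 1 to compound 2 (beyond the scatter) was large, a rise is expected for compound 4 in this assay, though the different surroundings and the single precedent argue for a wide band. The expected step is a number 17 percentage points higher from compound 3 to compound 4 (beyond the scatter). Compound 4 is estimated at 30%, with a band from 8% to 55%.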

Compound 4, a percentage reported as inhibition, at one concentration (the size of the read-out at that concentration, not a potency): 37%
Compound 4: middle estimate off by 7 percentage points, on the low side; the measured number falls inside the stated range.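

In this assay the step is a number 24 percentage points higher from compound 3 to compound 4 (beyond the scatter) for chloro in place of hydrogen on an aromatic carbon, so the rise seen on the core of compound 1 recurs on the core of compound 3. The two steps cannot be told apart in size on these data: the same change on two cores in this assay, a number 33 percentage points higher (beyond the scatter) from compound 1 to compound 2 and a number 24 percentage points higher (beyond the scatter) from compound 3 to compound 4, 9 percentage points apart, within the scatter of two such steps. This shows that the direction of the change held on both cores, but it rests on one pair per core, the chloro stands in different surroundings in the two pairs (in compound 4 ortho to a chloro group and meta to a group of 9 heavy atoms), and so it does not show that the step would hold on any further core or that the place of the chloro is without consequence.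

Still open, on these data alone, is whether a group other than chloro, such as bromo, methyl or methoxy, gives a similar rise at this place. Also open, as far as these compounds go, is how a carboxylic acid or an amide in place of the methyl ester would read on the core of compound 4.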